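The source may hold more compounds than are shown below. What is called first, only, known or untested is meant among the compounds shown, and "the series" means these compounds.

Measured compounds in an assay on HEK293 cells for displacement of a labelled ligand from Melanocortin receptor 4 (Homo sapiens); a lower number here means a stronger inhibitor, a higher number a weaker inhibitor:

compound 1 `COc1cc(CC(C)C(=O)N2CCN(c3ccc(C(F)(F)F)cc3[C@@H](N)CC(C)C)CC2)ccc1Cl` — 230 nM
compound 2 `CC(C)C[C@H](N)c1cc(C(F)(F)F)ccc1N1CCN(C(=O)C(C)Cc2ccc(Cl)cc2O)CC1` — 36 nM
compound 3 `COc1ccc(CC(C)C(=O)N2CCN(c3ccc(C(F)(F)F)cc3[C@@H](N)CC(C)C)CC2)cc1` — 120 nM

Compound 3 stands second highest of the three numbers. Its nearest neighbour lies within the scatter: a 1.9-fold lower number from compound 1 to compound 3 (0.28 log units; within the scatter). Its furthest lies beyond it: a 3.3-fold higher number from compound 2 to compound 3 (0.52 log units; beyond the scatter).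

Compound 4 `Cc1cc(CC(C)C(=O)N2CCN(c3ccc(C(F)(F)F)cc3[C@@H](N)CC(C)C)CC2)ccc1Cl` has not yet been measured. The change from compound 3 is 4-chloro-3-methylphenyl in place of 4-methoxyphenyl on a saturated chain carbon, two bonds along the chain from a carbonyl carbon. Of the measured steps, the one that bears most directly on it is a 1.9-fold lower number from compound 1 to compound 3 (0.28 log units; within the scatter), where a ring carrying both chlorine and methoxy was exchanged for one carrying methoxy alone, with no movement beyond the scatter. Compound 4 restores the chlorine and replaces the methoxy with methyl, so its ring is the closer relative of the ring in compound 1 than of that in compound 3. The other step, a 6.4-fold lower number from compound 1 to compound 2 (0.81 log units; beyond the scatter), introduced a hydroxyl and is a different kind of exchange; it is not taken as a guide here. Within the data shown here, no measured pair tells whether methyl in place of methoxy matters. The expectation for compound 4 is therefore a number near those of compounds 1 and 3, with a step of a 1.4-fold higher number from compound 3 to compound 4 (0.15 log units; within the scatter), not beyond the scatter. Compound 4 is estimated at 170 nM, in the range 70 nM to 420 nM.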

Compound 4, inhibition constant: 71 nM
Compound 4: middle estimate off by 2.4-fold (0.38 log units), on the high side; low and high end bracket the measured number.
By their numbers in this assay, from the lowest: compounds 2, 4, 3 and 1 (each within the scatter of the next, the first and the last beyond it).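

Among these compounds, the one new exchange that can be read on its own is methyl in place of methoxy on an aromatic carbon with the chlorine kept: a 3.2-fold lower number from compound 1 to compound 4 (0.51 log units; beyond the scatter) in this assay. Among the compounds shown here, it is a modest step, but it lies beyond the scatter, so this substituent registers at this position, which no earlier pair could show. The 4-chloro-3-methylphenyl group cannot be separated from 4-methoxyphenyl, at a 1.7-fold lower number from compound 3 to compound 4 (0.23 log units; within the scatter), or from 4-chloro-2-hydroxyphenyl, at a 2.0-fold higher number from compound 2 to compound 4 (0.29 log units; within the scatter), even though those two rings are themselves separated by a 3.3-fold higher number from compound 2 to compound 3 (0.52 log units; beyond the scatter), so a ring with no hydrogen-bond donor falls within the scatter of compound 2. No measurement bearing on why these steps take the size they do is available.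

Whether the chlorine contributes in its own right stays open, since no pair shown changes it alone, and the methyl exchange has been read only with that chlorine in place. From the compounds shown here alone, how a nitrile, an ethyl group or a fluorine in place of the methyl or the chlorine would read in this assay is also open.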